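This account rests on a few compounds, and the source may have more. Where it says the series, first, only, none or still open, it means among the compounds named here.

Working notes on the aryl ketone series.

The shared core carries an enone linked to a variable aryl group on the carbonyl carbon. Within the data shown here, compound 1 `O=C(/C=C/c1ccc2c(c1)B(O)OC2)c1ccco1` bears furan-2-yl there; in a functional assay on SK-OV-3 cells (Homo sapiens) for cytotoxicity, read by MTT assay, with a stated time of 48 h (on this read-out lower numbers stand for stronger inhibition and higher numbers for weaker inhibition), compound 1 gives 20700 nM, the highest of the three numbers measured so far. Compound 2 `O=C(/C=C/c1ccc2c(c1)B(O)OC2)c1cccnc1` bears pyridin-3-yl and gives 18500 nM in this assay; the step of a 1.1-fold lower number from compound 1 to compound 2 (0.05 log units; within the scatter) lies within the scatter. Among the measured compounds shown here, compound 3 `O=C(/C=C/c1ccc2c(c1)B(O)OC2)c1ccc([N+](=O)[O-])cc1` bears 4-nitrophenyl and gives 7900 nM; no single-point step to compound 1 is counted, but the two values stand apart beyond the scatter, with compound 3 the lower number.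

Compound 4 `O=C(/C=C/c1ccc2c(c1)B(O)OC2)c1ccccc1F` is now to be measured. Relative to compound 1 the change is 2-fluorophenyl in place of furan-2-yl on a carbonyl carbon. For the measured compounds named here, the one measured step that bears on it, a 1.1-fold lower number from compound 1 to compound 2 (0.05 log units; within the scatter), swaps one aromatic ring for another and moves nothing beyond the scatter. The only six-membered carbocyclic ring measured, in compound 3 at 7900 nM, gives the lowest number, though it carries a nitro group that compound 4 does not. A modest step toward lower numbers is therefore expected for compound 4, a 1.6-fold lower number from compound 1 to compound 4 (0.20 log units; within the scatter), with wide uncertainty. The estimate for compound 4 in this assay is 13000 nM, between 5500 nM and 32000 nM.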

Compound 4, half-maximal inhibitory concentration: 3700 nM
Compound 4: middle estimate off by 3.5-fold (0.55 log units), on the high side; the whole stated range lies above it.
By their numbers in this assay, from the lowest: compound 4; then compound 3; then compounds 2 and 1 (each within the scatter of the next).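

In this assay, the group on the carbonyl carbon proves able to move the number well beyond the scatter without a nitro group: 2-fluorophenyl gives a 5.6-fold lower number from compound 1 to compound 4 (0.75 log units; beyond the scatter) and, against the other ring containing a hetero atom, a 5.0-fold lower number from compound 2 to compound 4 (0.70 log units; beyond the scatter). The earlier swap of furan-2-yl for pyridin-3-yl had left this position looking flat, whereas across the four compounds the two six-membered rings of carbon only, compound 3 at 7900 nM and compound 4 at 3700 nM, now carry lower numbers than the two rings containing a hetero atom, with no compound shown going against that split. No measurement at hand accounts for the size of these steps.

Still open, going by these compounds, is how much of the step belongs to the carbon ring and how much to the fluorine, a split that a plain phenyl group on the carbonyl carbon would help to settle. Also open, on these data alone, is whether chlorine or an amine on the ring in place of the fluorine would hold the number near that of compound 4 or return it toward that of compound 1.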